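Removing the diethylamino group: expected effect on cell tolerance

The compounds below may be only part of what the source reports. "The series", "measured", "known", "first", "only" and "open" are said of these compounds alone.

Measured so far in an ADME assay on BHK cells (Mesocricetus auratus) for cytotoxicity, read by MTT assay, with a stated time of 96 h; a higher number here means that more compound is tolerated, a lower number that less compound is tolerated:
compound 1 `CC(=O)Nc1ccc(-c2nc3cc(C(F)(F)F)ccc3n2C)cc1` — > 100000 nM
compound 2 `CC(=O)Nc1ccc(-c2nc3cc([N+](=O)[O-])ccc3[nH]2)cc1` — > 100000 nM
compound 3 `CCN(CC)CC(=O)Nc1ccc(-c2nc3cc(C(F)(F)F)ccc3[nH]2)cc1` — 23000 nM

The value for compound 1 is a limit of the assay, not a number. The value for compound 2 is likewise a limit. Going by the values given here, compound 3 is the only compound with an actual number in this assay; the other two results sit at the limit of > 100000 nM in this assay, at which 2 of the 3 values shown sit. Compound 4 `CC(=O)Nc1ccc(-c2nc3cc(C(F)(F)F)ccc3[nH]2)cc1` differs from compound 3 in one place: hydrogen in place of diethylamino on a saturated chain carbon bound to a carbonyl carbon. Among the compounds with values here, no step between two measured compounds is available, so the size of this change can only be expected. Compound 4 is expected to be tolerated at a higher concentration, a step of a 4.3-fold higher number from compound 3 to compound 4 (0.64 log units; beyond the scatter), because both acetamido compounds sit at the limit of > 100000 nM in this assay, at which 2 of the 3 values shown sit. The estimate for compound 4 is 100000 nM, with a range from 30000 nM to 300000 nM.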

Compound 4, half-maximal cytotoxic concentration: 53000 nM
Beside the measured number, compound 4's estimate is 1.9-fold (0.28 log units) above it, and the stated range covers the measured number.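

In this assay, hydrogen in place of diethylamino on a saturated chain carbon bound to a carbonyl carbon gives a 2.3-fold higher number from compound 3 to compound 4 (0.36 log units; beyond the scatter). The gain is modest, and compound 4 still reaches a measured value of 53000 nM, so the diethylamino group does not account for all of the effect on the cells. Trifluoromethyl in place of nitro on an aromatic carbon gives an at least 1.8-fold lower number from compound 2 to compound 4 (0.27 log units; that floor lies within the scatter). Hydrogen in place of methyl on an aromatic nitrogen gives an at least 1.8-fold lower number from compound 1 to compound 4 (0.27 log units; that floor lies within the scatter). The results for compound 1 and compound 2 are limits of the assay, not numbers: the limit of > 100000 nM in this assay, at which 2 of the 4 values shown sit.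

The compounds shown leave open whether a smaller amine such as dimethylamino, a morpholine ring or a longer chain on this carbon would fall closer to compound 3 or compound 4.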